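Macrocyclic enone series: amide in place of amine

The source may hold more compounds than are shown below. What is called first, only, known or untested is meant among the compounds shown, and "the series" means these compounds.

Measured so far:
- compound 1 `CCN(CC)C/C1=C/C[C@](C)(CCC=C(C)C)/C=C/[C@@H](OC(=O)C=C(C)C)[C@](C)(O)/C=C/C1=O`: 270 nM
- compound 2 `CC(C)=CCC[C@](C)(/C=C/[C@@H](OC(=O)C=C(C)C)[C@](C)(O)/C=C/C(=O)/C=C/N1CCN(C)CC1)CC=O`: 12400 nM

In a functional assay on SW480 cells (Homo sapiens) for antiproliferative activity, read by MTT assay, with a stated time of 48 h (on this read-out higher numbers stand for weaker inhibition and lower numbers for stronger inhibition), compound 1 gives the lowest number of the two; compound 2 gives a higher number, and that gap lies beyond the scatter. Compound 3 `CC(C)=CCC[C@]1(C)/C=C/[C@@H](OC(=O)C=C(C)C)[C@](C)(O)/C=C/C(=O)/C(C(=O)N2CCCC2)=C\C1` differs from compound 1 by (pyrrolidin-1-yl)carbonyl in place of (diethylamino)methyl on a double-bonded ring carbon. Among the measured compounds shown here, no comparable step between measured compounds is known, so the expectation rests on the weaker compound 2 only. Compound 3 is expected to give a step of a 5.6-fold higher number from compound 1 to compound 3 (0.74 log units; beyond the scatter) towards weaker inhibition, moderate and beyond the scatter. Compound 3 is estimated at 1500 nM, with a range from 300 nM to 8000 nM.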

Compound 3, half-maximal inhibitory concentration: 15100 nM
For compound 3 the middle estimate is 10-fold (1.00 log units) below the measured one; the measured number lies above the stated range.
By their numbers in this assay, from the lowest: compound 1; then compounds 2 and 3 (each within the scatter of the next).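

In this assay, (pyrrolidin-1-yl)carbonyl in place of (diethylamino)methyl on the double-bonded ring carbon gives a 56-fold higher number from compound 1 to compound 3 (1.75 log units; beyond the scatter) and so marks a large loss for this exchange on the shared core. Among the compounds shown here, this is the first comparison at this carbon that differs in one place, which compound 2 could not supply. Nothing measured here explains the loss.

As far as these compounds go, the exchange changes both the carbonyl and the ring, so which of them carries the step remains open. (Pyrrolidin-1-yl)methyl or (diethylamino)carbonyl at this carbon would separate the two.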